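Ester in place of ethyl on the phenoxy ring

The source may report more compounds than this note shows. Statements on the series, on what has been measured and on what is new or still open speak of the compounds shown alone.

The measured compounds and their values:
Compound 1, `O=c1cc(-n2cc(CSc3ccccc3)nn2)c2cc(Br)ccc2o1`: 36800 nM
Compound 2, `O=c1cc(-n2cc(COc3ccccc3Br)nn2)c2cc(Br)ccc2o1`: 28900 nM
Compound 3, `CCc1ccc(OCc2cn(-c3cc(=O)oc4ccc(Br)cc34)nn2)cc1`: 12700 nM

In a functional assay on MCF7 cells (Homo sapiens) for antiproliferative activity, read by MTT assay, with a stated time of 48 h (a higher number here means a weaker inhibitor, a lower number a stronger inhibitor), compound 3 gives the lowest of the three numbers, ahead of compound 2 by a 2.3-fold lower number from compound 2 to compound 3 (0.36 log units; beyond the scatter) and ahead of compound 1 by a 2.9-fold lower number from compound 1 to compound 3 (0.46 log units; beyond the scatter). The two steps that reach compound 3 are therefore modest but beyond the scatter, and both change only the group at the end of the same side chain.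

Compound 4, `COC(=O)c1ccc(OCc2cn(-c3cc(=O)oc4ccc(Br)cc34)nn2)cc1`, is not yet measured in this assay. It differs from compound 3 by methoxycarbonyl in place of ethyl on an aromatic carbon, on an aromatic carbon of a six-membered aromatic ring of carbon only, para to a large group.

For the measured compounds named here, no measured pair swaps a substituent on this ring for one with hydrogen-bond acceptors, so there is no direct precedent. The nearest guide is the step from compound 2 to compound 3, a 2.3-fold lower number from compound 2 to compound 3 (0.36 log units; beyond the scatter), which shows that changing the substituent on this ring moves the number modestly. A step of similar size in either direction is expected, here a 1.3-fold higher number from compound 3 to compound 4 (0.10 log units; within the scatter). Compound 4 is thus estimated at 16000 nM, between 6000 nM and 42000 nM.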

Compound 4, half-maximal inhibitory concentration: 3130 nM
For compound 4 the middle estimate is 5.1-fold (0.71 log units) above the measured one; measured number outside the range, below it.
By their numbers in this assay, from the lowest: compound 4; then compound 3; then compounds 2 and 1 (each within the scatter of the next).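

In this assay, for the compounds shown here, the step of a 4.1-fold lower number from compound 3 to compound 4 (0.61 log units; beyond the scatter) is the first here that changes only the substituent on the ring, leaving the oxygen link and the rest of the molecule untouched. The earlier steps shown here changed the linking atom or moved from one substituted ring to another, so this one isolates the group on this aromatic carbon, para to a large group. Ethyl has no hydrogen-bond acceptors and methoxycarbonyl has some, and this swap is tolerated and lowers the number beyond the scatter, though no measurement here explains the shift.

The compounds shown cannot separate the larger size of methoxycarbonyl from its hydrogen-bond acceptors. A longer chain such as butyl, a carboxylic acid or an amide at the same place would help to tell these apart.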